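Two aryl swaps on one shared core in KM12 cells

The compounds below may be only part of what the source reports. "The series", "measured", "known", "first", "only" and "open" are said of these compounds alone.

Compound 1 `c1ccc2c(-c3cn4ccnc4c(-c4ccc5ncn(C6CCCCC6)c5c4)n3)cccc2c1` and compound 2 `c1cn2cc(-c3ccsc3)nc(-c3ccc4ncn(C5CCCCC5)c4c3)c2n1` share a core and differ only at one aromatic carbon, where compound 1 carries naphthalen-1-yl and compound 2 carries thiophen-3-yl. In a functional assay on KM12 cells (Homo sapiens) for inhibition, read by sulforhodamine B assay, with a stated time of 48 h, tested at 10 uM (on this read-out lower numbers stand for less inhibition and higher numbers for more inhibition at the one concentration tested (going by the name of the read-out)), compound 1 gives 11.1% and compound 2 gives 15.4%. Among the compounds with values here, the single step measured so far, a number 4.3 percentage points higher from compound 1 to compound 2 (within the scatter), lies within the scatter, so the two numbers cannot be told apart; compound 1 stands at the lowest of the two numbers, with compound 2 nearest, the gap within the scatter.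

Compound 3 `COc1ccccc1-c1cn2ccnc2c(-c2ccc3ncn(C4CCCCC4)c3c2)n1` has not yet been measured in this assay. It differs from compound 1 as follows: 2-methoxyphenyl in place of naphthalen-1-yl on an aromatic carbon. Within the data shown here, the only measured step that bears on this change is the exchange at the same aromatic carbon from compound 1 to compound 2, which stayed within the scatter; that step brought in thiophen-3-yl rather than 2-methoxyphenyl, so it speaks to the position but not to the entering group. On that basis no step beyond the scatter is expected, and the estimated change is a number 2.9 percentage points higher from compound 1 to compound 3 (within the scatter). Compound 3 is therefore expected to give about 14% in this assay, within a range from 0% to 32%.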

Compound 3, a percentage reported as inhibition, at one concentration (the size of the read-out at that concentration, not a potency): 3.58%
The estimate for compound 3 lay 10.4 percentage points above the measured number; the range from low to high includes it.
By their numbers in this assay, from the lowest: compounds 3, 1 and 2 (each within the scatter of the next, the first and the last beyond it).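

With 2-methoxyphenyl at this aromatic carbon, this assay shows a number 7.5 percentage points lower from compound 1 to compound 3 (within the scatter), so a single ring carrying a methoxy group cannot be told apart from the two-ring naphthalen-1-yl. Within the data shown here, the same entering group, set against thiophen-3-yl, gives a number 11.8 percentage points lower from compound 2 to compound 3 (beyond the scatter), which is the first step at this position to pass beyond the scatter, and it shows that the read-out is not wholly indifferent to the aryl group placed here, although the step is modest and compound 1 stays within the scatter of both neighbours. Nothing available accounts for this difference between the two exchanges.

On these data alone, all three groups at this position are aromatic rings and all three numbers are low, so it remains open whether any group here could raise inhibition well beyond this narrow band. As far as these compounds go, an aliphatic amine, a carboxylic acid or a longer alkyl chain on this carbon would test that, and the cyclohexyl group, the same in all three compounds, leaves the effect of any change elsewhere on the shared core equally open.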